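Bromo in place of hydrogen: what to expect

A few compounds are considered here, and "the series" means these few. Any claim that something is new, unique, unknown or untested is made for them only; others in the source may bear on it.

Measured so far:
compound 1, `COc1cc(OC)c(C(=O)/C=C/c2ccccc2)c(OC)c1`, gives 24%
compound 2, `COc1cc(O)c(C(=O)/C=C/c2ccccc2OC)c(OC)c1`, gives 37%

Compound 1 has the lowest of the two numbers shown, and compound 2 stands higher by a gap beyond the scatter. Compound 3, `COc1cc(OC)c(C(=O)/C=C/c2ccc(Br)cc2)c(OC)c1`, has not yet been measured. It differs from compound 1 in a single way: bromo in place of hydrogen on an aromatic carbon. Going by the values given here, no measured pair shows this change, so its size in a functional assay on Caco-2 cells (Homo sapiens), read by fluorescence and BrdU incorporation, with a stated time of 48 h, tested at 25 uM (a lower number here means a stronger effect, a higher number a weaker effect of the compound at the concentration tested), cannot be read from the data. The step from compound 1 to compound 3 is expected to be small, a number 4 percentage points higher from compound 1 to compound 3 (within the scatter), likely within the scatter. Compound 3 is therefore estimated at 28%, in a range from 10% to 50%.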

Compound 3, a percentage reported as activity, at one concentration (the size of the read-out at that concentration, not a potency): 1.9%
Estimate against measurement, compound 3: 26.1 percentage points above; the whole stated range lies above it.
By their numbers in this assay, from the lowest: compound 3; then compound 1; then compound 2.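

In this assay, the change from phenyl to 4-bromophenyl gives a number 22.1 percentage points lower from compound 1 to compound 3 (beyond the scatter), so a lower number here means a stronger effect at the concentration tested. This shows that the aromatic carbon para to a large group is not indifferent to substitution: a single bromo atom in place of hydrogen changes the read-out beyond the usual scatter.

As far as these compounds go, whether a smaller chloro, an amine or a carboxylic acid at this same carbon would move the number in the same direction remains open. Nothing available explains why bromo has this effect.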